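The source may hold more compounds than are shown below. What is called first, only, known or untested is meant among the compounds shown, and "the series" means these compounds.

Measured so far:
compound 1 `Cc1ncc([N+](=O)[O-])n1CCSc1nnc(-c2ccccc2)o1` — 17500 nM
compound 2 `Cc1ccccc1-c1nnc(SCCn2c([N+](=O)[O-])cnc2C)o1` — 5100 nM
compound 3 `Cc1ncc([N+](=O)[O-])n1CCSc1nnc(-c2cccs2)o1` — 20500 nM

In a functional assay on HepG2 cells (Homo sapiens) for cytotoxicity, read by MTT assay, with a stated time of 48 h (on this read-out lower numbers stand for stronger inhibition and higher numbers for weaker inhibition), compound 2 stands lowest of the three numbers: a 3.4-fold lower number from compound 1 to compound 2 (0.54 log units; beyond the scatter) and a 4.0-fold higher number from compound 2 to compound 3 (0.60 log units; beyond the scatter) both lie beyond the scatter. Compound 4 `Cc1ncc([N+](=O)[O-])n1CCSc1nnc(-c2ccc(N)nc2)o1` differs from compound 2 by 6-aminopyridin-3-yl in place of 2-methylphenyl on an aromatic carbon. Going by the values given here, two steps bear on this: the methyl gain gave a 3.4-fold lower number from compound 1 to compound 2 (0.54 log units; beyond the scatter), while swapping the ring on that carbon without a methyl gave only a 1.2-fold higher number from compound 1 to compound 3 (0.07 log units; within the scatter), within the scatter. Compound 4 carries no methyl, so the number is expected to move back up toward compounds 1 and 3, by about a 2.9-fold higher number from compound 2 to compound 4 (0.47 log units; beyond the scatter) in this assay. Compound 4 is therefore estimated at 15000 nM, range 6000 nM to 40000 nM.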

Compound 4, half-maximal inhibitory concentration: 9400 nM
For compound 4 the middle estimate is 1.6-fold (0.20 log units) above the measured one; the range from low to high includes it.
By their numbers in this assay, from the lowest: compounds 2, 4, 1 and 3 (each within the scatter of the next, the first and the last beyond it).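

In this assay, the ring bearing a hydrogen-bond donor and a ring nitrogen can be placed on this carbon without a clear separation from either carbon-ring group: a 1.8-fold higher number from compound 2 to compound 4 (0.27 log units; within the scatter) and a 1.9-fold lower number from compound 1 to compound 4 (0.27 log units; within the scatter) both stay within the scatter. Only thiophen-2-yl separates from it, with a 2.2-fold lower number from compound 3 to compound 4 (0.34 log units; beyond the scatter) lying beyond the scatter, though modestly. Compound 4 carries no methyl, yet it cannot be told apart from compound 2.

On these data alone, whether a plain aminophenyl or a carboxylic acid on this ring would behave alike remains open. No measurement on hand accounts for these steps.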